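The source may report more compounds than this note shows. Statements on the series, on what has been measured and on what is new or still open speak of the compounds shown alone.

Compound 1, with the structure `COc1cc(CNC(=O)/C=C/c2ccccc2O)ccc1O`, is the starting point. In a functional assay on SH-SY5Y cells (Homo sapiens) for cytotoxicity, read by MTT assay, with stated times of 24 h and 4 h (a higher number here means that more compound is needed for the effect, a lower number that less compound is needed), compound 1 gives 9760 nM. Compound 2, with the structure `COc1cc(CNC(=O)/C=C/c2ccccc2OCc2nc(C)c(C)nc2C)ccc1O`, carries one change against compound 1: (3,5,6-trimethylpyrazin-2-yl)methyl in place of hydrogen on an oxygen on an aromatic ring. In this assay compound 2 gives 12000 nM, so the step of a 1.2-fold higher number from compound 1 to compound 2 (0.09 log units; within the scatter) shows that this addition left the readout essentially where it was.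

Compound 3, with the structure `COc1ccc(/C=C/C(=O)NCc2ccc(OCc3nc(C)c(C)nc3C)c(OC)c2)cc1O`, has a different core from compound 1; how the two cores differ is not broken down here. In this assay compound 3 gives 8560 nM, which sits close to the numbers for compound 1 and compound 2.

Compound 4, with the structure `COc1cc(CNC(=O)/C=C/c2ccc(OC)c(OCc3nc(C)c(C)nc3C)c2)ccc1OCc1nc(C)c(C)nc1C`, is not yet measured. It differs from compound 3 in one place: (3,5,6-trimethylpyrazin-2-yl)methyl in place of hydrogen on an oxygen on an aromatic ring. This is the same change that turned compound 1 into compound 2, made at the same kind of place. Because that earlier step a 1.2-fold higher number from compound 1 to compound 2 (0.09 log units; within the scatter) stayed within the scatter, a similarly small step is expected here, a 1.2-fold higher number from compound 3 to compound 4 (0.07 log units; within the scatter). Compound 4 is therefore estimated to give 10000 nM, most likely between 5000 nM and 20000 nM.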

Compound 4, half-maximal effective concentration: 11600 nM
Compound 4: middle estimate off by 1.2-fold (0.06 log units), on the low side, within the range that was stated.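

In this assay, the new step, a 1.4-fold higher number from compound 3 to compound 4 (0.13 log units; within the scatter), is small, so adding (3,5,6-trimethylpyrazin-2-yl)methyl on an oxygen on an aromatic ring again left the readout essentially where it was. Set side by side, the two cases agree: the same change on two cores in this assay, a 1.2-fold higher number (0.09 log units; within the scatter) from compound 1 to compound 2 and a 1.4-fold higher number (0.13 log units; within the scatter) from compound 3 to compound 4, 1.1-fold (0.04 log units) apart, within the scatter of two such steps. This shows that, on these two cores, the change carries over as a step too small to separate from ordinary repeat variation, but it does not show that the same would hold on any other core, nor does it explain why the number barely moves.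

The compounds shown leave open what other groups on that oxygen would do, such as a chain ending in an amine, a carboxylic acid or a simple ethyl group. They also leave open whether this change would stay as small in a readout other than this cell test.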